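The source may report more compounds than this note shows. Statements on the series, on what has been measured and on what is new or still open speak of the compounds shown alone.

Measured compounds in an assay on HeLa cells for inhibition of Indoleamine 2,3-dioxygenase 1 (Homo sapiens), with stated times of 1 h and 18 h; a lower number here means a stronger inhibitor, a higher number a weaker inhibitor:
Compound 1 `Cc1ccc(NC(=O)Nc2cc(-c3ccccc3C(=O)O)ccc2N(C)c2ccccc2C(C)(C)C)cc1`, > 1000 nM (a limit of the assay, not a number; see (the limit of > 1000 nM in this assay, at which 1 of the 3 values shown sits))
Compound 2 `Cc1ccc(NC(=O)Nc2cc(-c3ccccc3C(=O)O)ccc2NC2CCCCC2)cc1`, 504 nM
Compound 3 `Cc1ccc(NC(=O)Nc2cc(-c3ccccc3C(=O)O)ccc2N(C)C2CCCCC2)cc1`, 14 nM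

Compound 3 stands lowest of the two numbers shown in this assay, with compound 2 the nearest, a 36-fold lower number from compound 2 to compound 3 (1.56 log units; beyond the scatter); compound 1 reports only a limit. Compound 4 `CCCCN(CCCC)c1ccc(-c2ccccc2C(=O)O)cc1NC(=O)Nc1ccc(C)cc1` has not yet been measured in this assay. It differs from compound 3 in one place: dibutylamino in place of cyclohexyl(methyl)amino on an aromatic carbon. Going by the values given here, two measured steps bear on this. The step from compound 2 to compound 3 shows that a methyl on that nitrogen, leaving no hydrogen-bond donor, gives a 36-fold lower number from compound 2 to compound 3 (1.56 log units; beyond the scatter). The step from compound 1 to compound 3 shows that cyclohexyl in place of 2-(tert-butyl)phenyl gives an at least 71-fold lower number from compound 1 to compound 3 (1.85 log units; beyond the scatter). Compound 4 keeps a nitrogen with no hydrogen-bond donor and no aryl group, but trades the ring for two chains. Compound 4 is therefore expected to stay closer to compound 3 than to compound 2, with a modest 2.9-fold higher number from compound 3 to compound 4 (0.46 log units; beyond the scatter) expected. The estimate for compound 4 in this assay is 40 nM, within 10 nM to 200 nM.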

Compound 4, half-maximal inhibitory concentration: 45 nM
For compound 4 the middle estimate is 1.1-fold (0.05 log units) below the measured one; measured number inside the range.
By their numbers in this assay, from the lowest: compound 3; then compound 4; then compound 2. At a limit, above all of these: compound 1.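

In this assay, the aromatic carbon para to a 2-carboxyphenyl group accepts an amine with no ring: dibutylamino gives a 3.2-fold higher number from compound 3 to compound 4 (0.51 log units; beyond the scatter), a modest cost for giving up cyclohexyl(methyl)amino. Dibutylamino in place of cyclohexylamino gives an 11-fold lower number from compound 2 to compound 4 (1.05 log units; beyond the scatter), so compound 3 and compound 4, the two with no hydrogen on that nitrogen and no aryl group on it, both stand well below compound 2. The step from methyl(2-(tert-butyl)phenyl)amino to dibutylamino starts from a limit, not a number, and is only a floor, an at least 22-fold lower number from compound 1 to compound 4 (1.34 log units; beyond the scatter): the limit of > 1000 nM in this assay, at which 1 of the 4 values shown sits.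

The compounds shown leave open whether shorter or longer chains, such as diethylamino or dipentylamino, would stay near compound 4. They also leave open how butyl(methyl)amino or a piperidine on that carbon would compare, which would help separate the loss of the ring from the added chain.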